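The source may hold more compounds than are shown below. What is called first, only, known or untested is meant among the compounds shown, and "the series" means these compounds.

Half-lives measured so far

compound 1 `O=C(NNS(=O)(=O)c1ccccc1F)c1cc(F)cc(-c2ccccn2)c1` with 0.933 h
compound 2 `Cc1cc(-c2ncccn2)cc(C(=O)NNS(=O)(=O)c2ccccc2)c1F` with 2.72 h
compound 3 `O=C(NNS(=O)(=O)c1ccccc1F)c1cccc(-n2cccn2)c1` with 2.35 h

These three compounds were tested in an ADME assay on microsomes from liver (Homo sapiens) for metabolic stability, read by HPLC, using NADPH, with a stated time of 60 min, tested at 1 uM, in the presence of a further agent that is not named here (a lower number here means that the compound disappears faster, a higher number that the compound lasts longer), and form a small set with varied structures. Compound 2, at 2.72 h in this read-out, lies within the scatter of compound 3 and beyond the scatter above compound 1. Compound 4 `Cc1cc(-n2nccn2)cc(C(=O)NNS(=O)(=O)c2ccccc2)c1F` shares the rest of its structure with compound 2 and carries 2H-1,2,3-triazol-2-yl in place of pyrimidin-2-yl on an aromatic carbon, para to a fluoro group and meta to a methyl group (2H-1,2,3-triazol-2-yl in place of pyrimidin-2-yl on an aromatic carbon). Among the compounds with values here, no two measured compounds differ in only one place, so the data give no direct guide to the size of this change in this assay for the series. A step beyond the scatter is therefore not expected. The estimated change is a 1.1-fold lower number from compound 2 to compound 4 (0.05 log units; within the scatter) and is expected to stay within the scatter. Compound 4 is estimated at 2.4 h with an expected range from 1.1 h to 5 h in this measurement.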

Compound 4, half-life: 1.02 h
For compound 4 the middle estimate is 2.4-fold (0.37 log units) above the measured one; measured number below the stated range.
By their numbers in this assay, from the lowest: compounds 1 and 4 (each within the scatter of the next); then compounds 3 and 2 (each within the scatter of the next).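

Within the data shown here, replacing pyrimidin-2-yl with 2H-1,2,3-triazol-2-yl gives a 2.7-fold lower number from compound 2 to compound 4 (0.43 log units; beyond the scatter) in this assay, and this is the first comparison in the set that isolates a single place. It shows that the half-life responds to the group on this aromatic carbon, para to a fluoro group and meta to a methyl group: exchanging one uncharged aromatic ring for another is enough to produce a step beyond the scatter. Nothing available accounts for the direction of this step.

The compounds shown leave open whether the same exchange gives a similar step on a different core, such as one carrying the fluoro group on the benzenesulfonyl ring. They also leave open how the half-life would respond at this position to a non-aromatic group such as morpholine or a simple amine.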